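The source may report more compounds than this note shows. Statements on the series, on what has been measured and on what is new or still open speak of the compounds shown alone.

Measured compounds:
compound 1 `COc1c(C)cnc(C[S+]([O-])c2nnc(-c3ccccc3)o2)c1C`: 7000 nM
compound 2 `[O-][S+](Cc1ccccc1)c1nnc(-c2ccccc2O)o1`: 8000 nM

Of the compounds shown here, two have been measured in a functional assay on HUVEC cells (Homo sapiens) for inhibition, read by ELISA; on this read-out lower numbers stand for stronger inhibition and higher numbers for weaker inhibition. Compound 1, with the structure `COc1c(C)cnc(C[S+]([O-])c2nnc(-c3ccccc3)o2)c1C`, gives 7000 nM in this assay. Compound 2, with the structure `[O-][S+](Cc1ccccc1)c1nnc(-c2ccccc2O)o1`, gives 8000 nM in this assay. The gap between these two numbers lies within the usual scatter of repeated measurements, so compound 1 and compound 2 cannot be told apart on this read-out, and compound 1 stands simply as one of two closely matched numbers. The two structures differ in several places at once, so no single change can be read from their values.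

The next compound, compound 3, has the structure `COc1c(C)cnc(C[S+]([O-])c2nnc(-c3ccc(F)cc3)o2)c1C`. It differs from compound 1 in one place only: fluoro in place of hydrogen on an aromatic carbon. Among the measured compounds shown here, no pair of measured compounds shows this kind of change, so nothing among the data gives its size in this assay. The step is expected to be small, in no set direction, and to stay within the scatter. Compound 3 is therefore estimated at 6000 nM in this assay, with a range from 2000 nM to 20000 nM. This estimate amounts to a step of a 1.2-fold lower number from compound 1 to compound 3 (0.07 log units; within the scatter).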

Compound 3, half-maximal inhibitory concentration: 14000 nM
The estimate for compound 3 lay 2.3-fold (0.37 log units) below the measured number; the measured number falls inside the stated range.
By their numbers in this assay, from the lowest: compounds 1, 2 and 3 (each within the scatter of the next).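

With compound 3, the shared core gains its first single-place comparison in this assay: on the phenyl ring, fluoro in place of hydrogen on an aromatic carbon, para to a large group, gives a 2.0-fold higher number from compound 1 to compound 3 (0.30 log units; within the scatter). The printed step lies within the scatter, so this read-out does not separate compound 3 from compound 1. No measurement is available that would explain this result.

The compounds shown leave open whether a different group at this same position, such as chloro, methoxy, an amine or a carboxylic acid, would give a step beyond the scatter in this assay. They also leave open whether fluoro would give a similar step on another carbon of this ring, or on the phenyl ring of a different core.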